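This account rests on a few compounds, and the source may have more. Where it says the series, first, only, none or still open, it means among the compounds named here.

Compound 1, `COc1cccc(-c2cc(C)c3ncc(CSCCc4ccccc4)n3c2)c1`, gives 20 ug/mL in an ADME assay on HEL cells (Homo sapiens) for cytotoxicity, with a stated time of 3 days; a lower number here means that less compound is tolerated, a higher number that more compound is tolerated.
Compound 2, `Cc1cc(I)cn2c(CSCCc3ccccc3)cnc12`, gives only the limit >= 0.8 ug/mL in this assay.
Compound 3, `Cc1cc(-c2cccc(C#N)c2)cn2c(CSCCc3ccccc3)cnc12`, gives only the limit > 100 ug/mL in this assay.

Compound 3 therefore has no number of its own in this assay: its value is the upper limit that the measurement can report, (the limit of > 100 ug/mL in this assay, at which 1 of the 3 values shown sits), and one other value among the three, that of compound 2, is also a limit, (the limit of >= 0.8 ug/mL in this assay, at which 1 of the 3 values shown sits). For the measured compounds named here, the one readable step among the measured compounds is an at least 5.0-fold higher number from compound 1 to compound 3 (0.69 log units; beyond the scatter), which is at least modest. The step that the limit leaves unreadable from compound 1 to compound 2 and the step that the two limits leave unreadable from compound 2 to compound 3 cannot be sized, since a limit sits at one end or both.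

Compound 4, `Cc1cc(-c2ccc(C#N)cc2)cn2c(CSCCc3ccccc3)cnc12`, is not yet measured. It differs from compound 3 by 4-cyanophenyl in place of 3-cyanophenyl on an aromatic carbon. Going by the values given here, no measured step compares these two placements of the cyano group; the step from compound 1 to compound 3 concerns a cyanophenyl only in that compound 3 carries one. With compound 3 already at the reporting limit and the two structures built from the same atoms, compound 4 is expected to show no step beyond the scatter, a number no higher from compound 3 to compound 4 (the limit leaves the size open). Compound 4 is estimated at 100 ug/mL, with a range of 35 ug/mL to 200 ug/mL.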

Compound 4, minimum cytotoxic concentration: >= 20 ug/mL
Compound 4: no number, only a limit; the forecaster's own chance of this, stated with the estimate: 60%; the middle value does not contradict the limit.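

The value of compound 4 is itself a limit and not a number: the limit of >= 20 ug/mL in this assay, at which 1 of the 4 values shown sits. Compared with compound 1, it still gives a direction, a number no lower from compound 1 to compound 4 (the limit leaves the size open), so 4-cyanophenyl at this position, like 3-cyanophenyl in compound 3, does not bring the number in this assay down from that of the compound carrying 3-methoxyphenyl. The steps to compound 4 from compound 2 and from compound 3 cannot be read, with limits at both ends, so the change from 3-cyanophenyl to 4-cyanophenyl has no size here.

As far as these compounds go, neither cyanophenyl compound has a number of its own, so whether the two differ at all in this assay stays open. Also open, from the compounds shown here alone, is what a carboxylic acid or an amine in place of the nitrile on that phenyl group would do to the number in this assay.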